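Para substituent swaps in a pyrazole amine series

A few compounds are considered here, and "the series" means these few. Any claim that something is new, unique, unknown or untested is made for them only; others in the source may bear on it.

Compound 3 `Cc1ccccc1-c1nn(-c2ccc([N+](=O)[O-])cc2)cc1CNCCN1CCN(C)CC1` carries a nitro group on the phenyl ring attached to the core. In an ADME assay on Huh-7 cells (Homo sapiens) for cytotoxicity (a higher number here means that more compound is tolerated, a lower number that less compound is tolerated), compound 3 gives > 20000 nM, which is a limit of the assay and not a number; it sits at the limit of > 20000 nM in this assay, at which 1 of the 3 values shown sits, so where compound 3 truly stands is known only as a floor. Compound 1 `Cc1ccccc1-c1nn(-c2ccc(Cl)cc2)cc1CNCCN1CCN(C)CC1` with chloro at the same position gives 17000 nM in this assay. Compound 2 `CSc1ccc(-n2cc(CNCCN3CCN(C)CC3)c(-c3ccccc3C)n2)cc1` with methylsulfanyl there gives 17000 nM in this assay.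

Compound 4 `Cc1ccccc1-c1nn(-c2ccc(F)cc2)cc1CNCCN1CCN(C)CC1` is next, and it differs from compound 3 as follows: fluoro in place of nitro on an aromatic carbon.

The measured steps that bear on this are the earlier swaps at the same aromatic carbon. no change at the digits printed from compound 1 to compound 2 (within the scatter). an at least 1.1-fold higher number from compound 1 to compound 3 (0.07 log units; that floor lies within the scatter). an at least 1.1-fold higher number from compound 2 to compound 3 (0.07 log units; that floor lies within the scatter). For the measured compounds named here, all three lie within the scatter, so none of the para groups tried so far has moved the half-maximal cytotoxic concentration measurably, and with compound 3 known only as a limit the step to a fluoro group has no measured counterpart that exceeds the scatter.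

For compound 4 the expected step is an at least 1.1-fold lower number from compound 3 to compound 4 (0.04 log units; that floor lies within the scatter), that is no change beyond the scatter. Compound 4 is therefore estimated at 18000 nM in this assay, within a range from 9000 nM to 36000 nM.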

Compound 4, half-maximal cytotoxic concentration: > 20000 nM
Compound 4 was reported as a limit; the forecaster's own chance of this, stated with the estimate: 40%; at least 1.1-fold (0.04 log units) between middle value and limit.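

In this assay compound 4 gives > 20000 nM, which is a limit of the assay and not a number. Fluoro in place of methylsulfanyl gives an at least 1.1-fold higher number from compound 2 to compound 4 (0.07 log units; that floor lies within the scatter), and fluoro in place of chloro gives an at least 1.1-fold higher number from compound 1 to compound 4 (0.07 log units; that floor lies within the scatter), while the step between compound 3 and compound 4 cannot be read, as both values are limits. With both readable floors inside the scatter, this aromatic carbon still shows no measurable effect across four different groups, and a small fluoro now reaches the same ceiling as nitro, so that ceiling is no longer tied to a single group: the limit of > 20000 nM in this assay, at which 2 of the 4 values shown sit.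

Where compound 3 and compound 4 truly stand remains unknown, so any real difference among the four groups could lie hidden beyond the limit of the assay. Whether this position can move the half-maximal cytotoxic concentration at all stays open, and an amine or a carboxylic acid on the same aromatic carbon would put that question to a group of a different kind from the four shown.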